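A few compounds are considered here, and "the series" means these few. Any claim that something is new, unique, unknown or untested is made for them only; others in the source may bear on it.

Compound 1 `CC(C)(C)c1ccc(NC(=O)c2csc(Cc3c(Cl)cccc3Cl)n2)cc1` gives 570 nM in an assay on CHO cells, read by calcium flux; on this read-out lower numbers stand for stronger inhibition and higher numbers for weaker inhibition. Compound 2 `O=C(Nc1ccc(C(F)(F)F)cc1)c1csc(Cc2c(Cl)cccc2Cl)n1` gives 140 nM in this assay.

Among the measured compounds shown here, compound 2 holds the lowest of the two numbers in this assay; the one measured step is a 4.1-fold lower number from compound 1 to compound 2 (0.61 log units; beyond the scatter), a modest change. Compound 3 `O=C(Nc1ccc(C(F)(F)C(F)(F)F)cc1)c1csc(Cc2c(Cl)cccc2Cl)n1` carries a further change at the same group: trifluoromethyl in place of fluoro on a saturated chain carbon bound to an aromatic carbon and two fluorine atoms. For the measured compounds named here, no measured step covers this exact exchange, and the single step on hand altered a different group, so it gives little guidance on direction. For compound 3 a step no larger than the scatter is expected, a 1.4-fold higher number from compound 2 to compound 3 (0.15 log units; within the scatter). Compound 3 is therefore estimated at 200 nM, within the range 70 nM to 600 nM.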

Compound 3, half-maximal inhibitory concentration: 290 nM
For compound 3 the middle estimate is 1.5-fold (0.16 log units) below the measured one, within the range that was stated.
By their numbers in this assay, from the lowest: compound 2; then compounds 3 and 1 (each within the scatter of the next).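

In this assay extending trifluoromethyl to 1,1,2,2,2-pentafluoroethyl on the aromatic carbon gives a 2.1-fold higher number from compound 2 to compound 3 (0.32 log units; beyond the scatter) and so shows that more fluorinated chain here does not lower the number further. Replacing tert-butyl with 1,1,2,2,2-pentafluoroethyl gives a 2.0-fold lower number from compound 1 to compound 3 (0.29 log units; within the scatter) and leaves those two groups without a readable order. No measurement on hand explains the change.

The compounds shown leave open how an amine or a carboxylic acid at this place would compare with trifluoromethyl. They also leave open whether a longer fluorinated chain would raise the number again.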